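A few compounds are considered here, and "the series" means these few. Any claim that something is new, unique, unknown or untested is made for them only; others in the source may bear on it.

Measured compounds:
Compound 1, `COc1cc2c(/C=C3/C(=O)N(C)c4ccccc43)c(Cl)n(C)c2cc1C`: 4070 nM
Compound 2, `COc1cc2c(/C=C3/C(=O)N(C)c4ccc(O)cc43)c(Cl)n(C)c2cc1C`: 470 nM
Compound 3, `COc1cc2c(/C=C3/C(=O)N(C)c4ccccc43)c[nH]c2cc1C`: 35500 nM

All three were tested in a functional assay on cells (Leukemia cell, Homo sapiens) for inhibition, with a stated time of 48 h; a lower number here means a stronger inhibitor of growth, a higher number a weaker inhibitor of growth. Compound 1 and compound 2 share a core and differ by one change, (hydroxy in place of hydrogen on an aromatic carbon), which gave an 8.7-fold lower number from compound 1 to compound 2 (0.94 log units; beyond the scatter). Compound 3 carries a different core; the difference between the two cores is not broken down here, and in this assay compound 3 gives 35500 nM, the highest number among the three.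

Compound 4, `COc1cc2c(/C=C3/C(=O)N(C)c4ccc(O)cc43)c[nH]c2cc1C`, has not yet been measured. It stands to compound 3 as compound 2 stands to compound 1: the change is hydroxy in place of hydrogen on an aromatic carbon, the same change seen from compound 1 to compound 2.

Because the change from compound 1 to compound 2 gave an 8.7-fold lower number from compound 1 to compound 2 (0.94 log units; beyond the scatter), a step of similar size and direction is expected for compound 4, namely a 7.9-fold lower number from compound 3 to compound 4 (0.90 log units; beyond the scatter). This rests on a single measured example, so the expectation is loose. Compound 4 is therefore estimated at 4500 nM, with a plausible range from 1500 nM to 15000 nM.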

Compound 4, concentration for total growth inhibition: 36300 nM
For compound 4 the middle estimate is 8.1-fold (0.91 log units) below the measured one; measured number outside the range, above it.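

In this assay, putting hydroxy in place of hydrogen on an aromatic carbon of the core of compound 3 gave a 1.0-fold higher number from compound 3 to compound 4 (0.01 log units; within the scatter), so on this core the change left growth inhibition where it was. The clear gain seen on the other core did not carry over, and the two steps differ by more than repeated measurement would explain: the same change on two cores in this assay, an 8.7-fold lower number (0.94 log units; beyond the scatter) from compound 1 to compound 2 and a 1.0-fold higher number (0.01 log units; within the scatter) from compound 3 to compound 4, 8.9-fold (0.95 log units) apart, beyond the scatter of two such steps. For the compounds shown here, this shows that the result of this change depends on the core that carries it, but with only one pair on each core, it does not show which difference between the cores is responsible, or why.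

The compounds shown leave open whether the hydroxy step would survive on a core that differs from either of these in only one place, which could separate the core differences from one another. They also leave open how an amine or a carboxylic acid in the same place would behave on each core.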